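The source may report more compounds than this note shows. Statements on the series, on what has been measured and on what is new or still open speak of the compounds shown alone.

Compound 3 `COc1cc2ncnc(NCc3cccc(NC(=O)Nc4ccc(C)cc4)c3)c2cc1OC` gives 34200 nM in a functional assay on MGC-803 cells (Homo sapiens) for antiproliferative activity, read by MTT assay (a lower number here means a stronger inhibitor, a higher number a weaker inhibitor), and compound 2 `COc1ccccc1NC(=O)Nc1cccc(CNc2ncnc3ccccc23)c1` gives 39300 nM in this assay, a gap within the scatter, so the two are not ordered. Compound 1 `Cc1ccccc1NC(=O)Nc1cccc(CNc2ncnc3ccccc23)c1` reaches only a limit, > 50000 nM, in this assay (the limit of > 50000 nM in this assay, at which 1 of the 3 values shown sits). Going by the values given here, the single measured step, an at least 1.2-fold lower number from compound 1 to compound 2 (0.10 log units; that floor lies within the scatter), swaps substituents on the urea aryl ring and reaches no size beyond the scatter. Among the compounds with values here, compound 4 `COc1cc2ncnc(NCc3cccc(NC(=O)Nc4ccccc4Cl)c3)c2cc1OC` differs from compound 3 by 2-chlorophenyl in place of 4-methylphenyl on an amide-type nitrogen, again a change on the urea aryl ring, and no measured step touches the chloro group. The expected step of a 1.1-fold lower number from compound 3 to compound 4 (0.06 log units; within the scatter) is therefore none beyond the scatter. Compound 4 is estimated at 30000 nM in this assay, between 10000 nM and 90000 nM.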

Compound 4, half-maximal inhibitory concentration: 30200 nM
The estimate for compound 4 lay 1.0-fold (0.00 log units) below the measured number, and the stated range covers the measured number.
By their numbers in this assay, from the lowest: compounds 4, 3 and 2 (each within the scatter of the next). At a limit, above all of these: compound 1.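

In this assay, the change on the amide-type nitrogen gives a 1.1-fold lower number from compound 3 to compound 4 (0.05 log units; within the scatter), so 2-chlorophenyl and 4-methylphenyl are not told apart here. This is the first step shown on the core of compound 3, and the first to bring in chlorine, and it reaches no size beyond the scatter.

Open, on these data alone, is whether an amine or a carboxylic acid on the urea aryl ring, or a longer chain in place of that ring, would give a step beyond the scatter. One value in the set remains a limit and not a number: the limit of > 50000 nM in this assay, at which 1 of the 4 values shown sits.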